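Methoxycarbonyl Replaces Hexylcarbamoyl in Compound 4

The compounds below may be only part of what the source reports. "The series", "measured", "known", "first", "only" and "open" are said of these compounds alone.

Of the compounds shown here, three have been measured in a functional assay on OVCAR-3 cells (Homo sapiens) for antiproliferative activity; on this read-out higher numbers stand for weaker inhibition of growth and lower numbers for stronger inhibition of growth. Compound 3 `CCCCCCNC(=O)c1cc(CCc2cc(O)ccc2O)ccc1O` gives 2400 nM in this assay, while compound 1 `CCCCCCNC(=O)c1cc(/C=C\c2cc(OC)ccc2OC)ccc1OC` gives 16100 nM. Compound 2 `CCCCCCNC(=O)c1cc(C#Cc2cc(OC)ccc2OC)ccc1OC` returns only a limit in this assay, > 100000 nM, which is a boundary of the measurement and not a number. Compound 2 thus stands at the limit of > 100000 nM in this assay, at which 1 of the 3 values shown sits. Compound 4 `COC(=O)c1cc(C#Cc2cc(OC)ccc2OC)ccc1OC` has not yet been measured in this assay. It differs from compound 2 in a single place: methoxy in place of hexylamino on a carbonyl carbon. Within the data shown here, no pair of measured compounds shows this change, so the data give no measured step to lean on. The change from compound 2 to compound 4 is expected to be small, with a step that the limit leaves unreadable from compound 2 to compound 4, because compound 2 stands at the limit of > 100000 nM in this assay, at which 1 of the 3 values shown sits. Compound 4 is therefore estimated to give 150000 nM in this assay, within a range of 30000 nM to 600000 nM, most likely again as a limit rather than a number.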

Compound 4, concentration for 50% growth inhibition: 13600 nM
Estimate against measurement, compound 4: 11-fold (1.04 log units) above; measured number outside the range, below it.
By their numbers in this assay, from the lowest: compound 3; then compounds 4 and 1 (each within the scatter of the next). At a limit, above all of these: compound 2.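

In this assay, methoxy in place of hexylamino on this carbonyl carbon gives an at least 7.3-fold lower number from compound 2 to compound 4 (0.86 log units; beyond the scatter). Among these compounds, this is the first measured step at this position, and it shows that, on the shared core of compound 4, hexylcarbamoyl is not required for a measurable number. The step gives only a bound on the true size of the change: the limit of > 100000 nM in this assay, at which 1 of the 4 values shown sits.

The compounds shown leave open whether the step comes from methoxy entering or hexylamino leaving. They also leave open how a carboxylic acid or an amide with a shorter chain would read on this carbonyl carbon.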